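The compounds below may be only part of what the source reports. "The series", "measured", "known", "first", "only" and "open" are said of these compounds alone.

Compound 1 `COc1cc2c(c(O)c1OC)C(=O)[C@]1(OC)C=C[C@H]2N(C(=O)OCC(C)C)N1C(=O)OCC(C)C` carries a free hydroxy on the aromatic ring of the shared core and isobutyl carbamates on both nitrogens. In an ADME assay on KB cells (Homo sapiens) for cytotoxicity (on this read-out higher numbers stand for an effect only at larger amounts of compound and lower numbers for an effect already at smaller amounts), compound 1 gives only a limit, > 300 ug/mL, so no number stands for it; what is known of its place is the limit of > 300 ug/mL in this assay, at which 1 of the 3 values shown sits. Compound 2 `CCOC(=O)N1[C@@H]2C=C[C@@](OC)(C(=O)c3c2cc(OC)c(OC)c3OCc2ccc(F)cc2)N1C(=O)OCC` and compound 3 `CCOC(=O)N1[C@@H]2C=C[C@@](OC)(C(=O)c3c2cc(OC)c(OC)c3OCc2ccccc2)N1C(=O)OCC` carry ethyl carbamates and a benzyl ether on that oxygen. In this assay compound 2 gives 51.8 ug/mL and compound 3 gives 215 ug/mL; the step is a 4.2-fold higher number from compound 2 to compound 3 (0.62 log units; beyond the scatter). That step sets one benzyl ether against another and does not itself cover the turning of a free hydroxy into an ether.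

Compound 4 `COc1ccc(COc2c(OC)c(OC)cc3c2C(=O)[C@]2(OC)C=C[C@H]3N(C(=O)OCC(C)C)N2C(=O)OCC(C)C)cc1` is the next compound for this assay. Against compound 1 the change is 4-methoxybenzyl in place of hydrogen on an oxygen on an aromatic ring. Among the measured compounds shown here, no measured step matches this change. What the series shows is that the two benzyl ethers, compound 2 and compound 3, returned numbers in this assay, whereas compound 1 returned only a limit. The expectation for compound 4 is thus a number rather than a limit, in the region of the benzyl ethers. The step expected from the limit is an at least 2.0-fold lower number from compound 1 to compound 4 (0.30 log units; that floor lies within the scatter). For compound 4 the estimate in this assay is 150 ug/mL, with a range from 50 ug/mL to 300 ug/mL.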

Compound 4, concentration for half-maximal effect: 47.9 ug/mL
Compound 4: the middle estimate sits 3.1-fold (0.50 log units) above what was measured; measured number outside the range, below it.
By their numbers in this assay, from the lowest: compounds 4 and 2 (each within the scatter of the next); then compound 3. At a limit, above all of these: compound 1.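

In this assay, among the compounds shown here, replacing the free hydroxy with (4-methoxybenzyl)oxy on the isobutyl carbamate compounds gives an at least 6.2-fold lower number from compound 1 to compound 4 (0.79 log units; beyond the scatter), the first step that sets a free hydroxy against an ether at this oxygen. Compound 1 remains a limit and not a number, so this step gives only a floor and its full size cannot be read: the limit of > 300 ug/mL in this assay, at which 1 of the 4 values shown sits. For the compounds shown here, the earlier step, a 4.2-fold higher number from compound 2 to compound 3 (0.62 log units; beyond the scatter), showed only that the number moves between two benzyl ethers, whereas this pair shows that the change from hydrogen to 4-methoxybenzyl on this oxygen brings the read-out from a limit to a measured number. Compound 4 stands at 47.9 ug/mL.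

Going by these compounds, it remains open whether the aromatic ring of the 4-methoxybenzyl group is needed for this step, and a methyl ether or a longer alkyl chain on the same oxygen would separate the ring from the loss of the free hydroxy. On these data alone, the part played by the methoxy group also remains open, and a plain benzyl ether carrying the isobutyl carbamates, or an amine in place of that methoxy, would test it directly.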